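Compound 4: Methoxy Replaces Fluoro on Compound 3

The compounds below may be only part of what the source reports. "The series", "measured", "known", "first", "only" and "open" are said of these compounds alone.

compound 1 `CC(=O)N(C)c1ccc2[nH]c(-c3n[nH]c4ccccc34)cc2n1` gives 23400 nM
compound 2 `CN(C(=O)c1ccccc1)c1ccc2[nH]c(-c3n[nH]c4ccccc34)cc2n1` gives 12500 nM
compound 3 `CN(C(=O)c1ccc(F)cc1)c1ccc2[nH]c(-c3n[nH]c4ccccc34)cc2n1` gives 9150 nM

In a functional assay on SMMC-7721 cells (Homo sapiens) for antiproliferative activity, read by MTT assay, with a stated time of 72 h (on this read-out lower numbers stand for stronger inhibition and higher numbers for weaker inhibition), compound 3 gives 9150 nM and cannot be separated from compound 2 (a 1.4-fold lower number from compound 2 to compound 3 (0.14 log units; within the scatter)), while it stands modestly clear of compound 1 (a 2.6-fold lower number from compound 1 to compound 3 (0.41 log units; beyond the scatter)). The remaining step (a 1.9-fold lower number from compound 1 to compound 2 (0.27 log units; within the scatter)) is also small. Compound 4 (`COc1ccc(C(=O)N(C)c2ccc3[nH]c(-c4n[nH]c5ccccc45)cc3n2)cc1`) keeps the rest of compound 3 and carries methoxy in place of fluoro on an aromatic carbon, para to a large group (methoxy in place of fluoro on an aromatic carbon). For the measured compounds named here, only one measured step touches that place, fluoro in place of hydrogen (a 1.4-fold lower number from compound 2 to compound 3 (0.14 log units; within the scatter)), and it stayed within the scatter. Going by the values given here, no tested compound carries methoxy, so the data give no direct guide to this replacement. A step beyond the scatter is therefore not expected, and no direction is favoured. The estimated step (a 1.1-fold higher number from compound 3 to compound 4 (0.04 log units; within the scatter)) is accordingly small. Compound 4 is expected at 10000 nM on this read-out, with an estimated range from 5000 nM to 20000 nM around it.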

Compound 4, half-maximal inhibitory concentration: 23700 nM
Estimate against measurement, compound 4: 2.4-fold (0.37 log units) below; the measured number lies above the stated range.
By their numbers in this assay, from the lowest: compounds 3, 2, 1 and 4 (each within the scatter of the next, the first and the last beyond it).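

In this assay, this place on the aromatic ring proved able to shift the number: methoxy in place of fluoro gives a 2.6-fold higher number from compound 3 to compound 4 (0.41 log units; beyond the scatter), whereas the earlier fluoro-for-hydrogen step, a 1.4-fold lower number from compound 2 to compound 3 (0.14 log units; within the scatter), did not separate its two compounds. Methoxy in place of hydrogen remains unresolved at a 1.9-fold higher number from compound 2 to compound 4 (0.28 log units; within the scatter), and 4-methoxyphenyl in place of methyl on the carbonyl carbon gives a 1.0-fold higher number from compound 1 to compound 4 (0.01 log units; within the scatter), so the modest separation seen with the 4-fluorophenyl group does not carry over to the 4-methoxyphenyl group. No available evidence bears on this difference between fluoro and methoxy.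

The compounds shown leave open how other groups at this place would read, such as chloro, hydroxyl, an amine or a carboxylic acid. As far as these compounds go, it also stays open whether the step from fluoro to methoxy would be the same elsewhere on this six-membered aromatic ring.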